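Chain extension on the amide: compound 3

This account rests on a few compounds, and the source may have more. Where it says the series, first, only, none or still open, it means among the compounds named here.

Measured in a functional assay on DU-145 cells (Homo sapiens) for cytotoxicity (a lower number here means a stronger inhibitor of growth, a higher number a weaker inhibitor of growth), so far
compound 1 `CCCCCCNC(=O)c1cc(NCc2cc(O)ccc2O)ccc1O` gives 15000 nM as its value
compound 2 `O=C(NCc1ccccc1)c1cc(NCc2cc(O)ccc2O)ccc1O` gives 16000 nM as its value

Among the compounds with values here, compound 1 stands level with compound 2 in this assay, the only measured step being a 1.1-fold higher number from compound 1 to compound 2 (0.03 log units; within the scatter) and thus within the scatter. Compound 3 `CCCCCCCCCCCCNC(=O)c1cc(NCc2cc(O)ccc2O)ccc1O`, not yet measured, differs from compound 1 by hexyl in place of hydrogen on a saturated chain carbon, six bonds along the chain from an amide-type nitrogen on a saturated chain carbon, six bonds along the chain from an amide-type nitrogen.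

Within the data shown here, the single measured step, phenyl in place of pentyl, falls on the same chain but does not lengthen it, so it is only a weak guide. Among the measured compounds shown here, no measured step shows what a longer chain does. A modest move towards a lower number is expected, though no change beyond the scatter remains possible. The expected step is a 1.9-fold lower number from compound 1 to compound 3 (0.27 log units; within the scatter) in this estimate. For compound 3 the estimated value is 8000 nM, with an expected range from 2500 nM to 25000 nM in this assay.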

Compound 3, concentration for 50% growth inhibition: 11000 nM
The estimate for compound 3 lay 1.4-fold (0.14 log units) below the measured number; the range from low to high includes it.
By their numbers in this assay, from the lowest: compounds 3, 1 and 2 (each within the scatter of the next).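

In this assay, within the data shown here, the first change that lengthens the chain on the amide, hexyl in place of hydrogen on a saturated chain carbon, six bonds along the chain from an amide-type nitrogen, gives a 1.4-fold lower number from compound 1 to compound 3 (0.13 log units; within the scatter) and so stays within the scatter. Among these compounds, at this position, the added hexyl leaves compound 3 level with compound 1, and the series so far shows no dependence on chain length across this one pair. No measured property bears on this result, and nothing can be said of its cause.

Still open, going by these compounds, is whether a chain carrying an amine or a carboxylic acid would give a step beyond the scatter in this assay. Also open, on these data alone, is whether a shorter chain such as butyl, or a longer chain than that of compound 3, would stay level with compound 1.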